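The source may hold more compounds than are shown below. What is called first, only, known or untested is meant among the compounds shown, and "the series" means these compounds.

For the measured compounds named here, in a functional assay on MOLT-4 cells (Homo sapiens), read by MTT assay, with a stated time of 72 h (a higher number here means a weaker inhibitor, a lower number a stronger inhibitor), compound 2 `COc1cc(NC(C)CCCNC(=O)NCc2ccccc2)c2ncccc2c1` gives 21000 nM, the lowest of the three numbers measured so far. Compound 1 `CCN(CC)C(=O)NCCCC(C)Nc1cc(OC)cc2cccnc12` gives 155000 nM and compound 3 `COc1cc(NC(C)CCCNC(=O)N(C2CCCCC2)C2CCCCC2)c2ncccc2c1` gives 36000 nM, the latter within the scatter of compound 2. Compound 4 `COc1cc(NC(C)CCCNC(=O)n2nnc3ccccc32)c2ncccc2c1` carries a group of 9 heavy atoms (6 carbon, 3 nitrogen; one five-membered aromatic ring with 3 hetero atoms, one six-membered aromatic ring of carbon only) in place of a group of 8 heavy atoms (7 carbon, 1 nitrogen; one six-membered aromatic ring of carbon only), on a carbonyl carbon. Going by the values given here, the only measured step at the same place is a 7.4-fold lower number from compound 1 to compound 2 (0.87 log units; beyond the scatter), so changing the group on the carbonyl carbon has moved the number beyond the scatter once, while compound 2 and compound 3 differ there without any gap beyond the scatter. Among the compounds with values here, no measured step involves a group resembling the entering one, so compound 4 is expected to stay near compound 2, a 1.2-fold higher number from compound 2 to compound 4 (0.08 log units; within the scatter). Compound 4 is estimated at 25000 nM, within a range of 8000 nM to 80000 nM.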

Compound 4, half-maximal inhibitory concentration: 74000 nM
Compound 4: middle estimate off by 3.0-fold (0.47 log units), on the low side, and the stated range covers the measured number.
By their numbers in this assay, from the lowest: compounds 2 and 3 (each within the scatter of the next); then compound 4; then compound 1.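

In this assay, replacing benzylamino on the carbonyl carbon with the group carrying 0 hydrogen-bond donors and 3 hydrogen-bond acceptors gives a change beyond the scatter (a 3.5-fold higher number from compound 2 to compound 4 (0.55 log units; beyond the scatter)), so this position does not tolerate every aromatic group equally. The same group still reads lower than diethylamino (a 2.1-fold lower number from compound 1 to compound 4 (0.32 log units; beyond the scatter)), placing it between the two earlier groups. Nothing available explains either step. Open, on these data alone, is how a phenylamino or morpholine group on this carbonyl carbon would read, and whether the amide hydrogen of benzylamino contributes to its lower number.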